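The source may hold more compounds than are shown below. What is called first, only, known or untested is meant among the compounds shown, and "the series" means these compounds.

In a functional assay on CCRF-CEM cells (Homo sapiens), read by MTT assay, with a stated time of 72 h (a lower number here means a stronger inhibitor, a higher number a weaker inhibitor), compound 3 `Cc1ncnc2c1c(-c1ccoc1)cn2[C@@H]1O[C@H](CO)[C@@H](O)[C@H]1O` gives > 20000 nM, which is a limit of the assay and not a number. Its place on the scale is thus only (the limit of > 20000 nM in this assay, at which 1 of the 3 values shown sits). For the measured compounds named here, compound 2 `CN(C)c1ncnc2c1c(-c1ccoc1)cn2[C@@H]1O[C@H](CO)[C@@H](O)[C@H]1O`, which also bears furan-3-yl, gives 13300 nM, and the one measured step is an at least 1.5-fold higher number from compound 2 to compound 3 (0.17 log units; that floor lies within the scatter). That step concerns another group, so it does not bear directly on the change to compound 4 `Cc1ncnc2c1c(-c1cc3ccccc3o1)cn2[C@@H]1O[C@H](CO)[C@@H](O)[C@H]1O`, which has 1-benzofuran-2-yl in place of furan-3-yl on an aromatic carbon. The closest guide is compound 1 `COc1ncnc2c1c(-c1cc3ccccc3o1)cn2[C@@H]1O[C@H](CO)[C@@H](O)[C@H]1O`, which also bears 1-benzofuran-2-yl and gives 5370 nM, so a lower number in this assay is expected. The expected change is an at least 2.5-fold lower number from compound 3 to compound 4 (0.39 log units; beyond the scatter). For compound 4 the estimated value is 8000 nM, within an expected range of 2500 nM to 20000 nM.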

Compound 4, half-maximal inhibitory concentration: 17300 nM
For compound 4 the middle estimate is 2.2-fold (0.33 log units) below the measured one, within the range that was stated.
By their numbers in this assay, from the lowest: compound 1; then compounds 2 and 4 (each within the scatter of the next). At a limit, above all of these: compound 3.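

In this assay, 1-benzofuran-2-yl in place of furan-3-yl gives an at least 1.1-fold lower number from compound 3 to compound 4 (0.06 log units; that floor lies within the scatter), so the larger group at this place shows no gain that can be told from the scatter. That step is only a floor, as compound 3 stands at a limit of the assay: the limit of > 20000 nM in this assay, at which 1 of the 4 values shown sits. With 1-benzofuran-2-yl kept, methyl in place of methoxy gives a 3.2-fold higher number from compound 1 to compound 4 (0.51 log units; beyond the scatter), so this change, and not the swap of rings, gives the one clear shift. On these data alone, how a primary amide or a longer alkyl chain would read at this place stays open.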